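The source may hold more compounds than are shown below. What is called first, only, known or untested is meant among the compounds shown, and "the series" means these compounds.

Measured so far:
- compound 1 `CC(C)c1ccc(C(C)C)c(C(=O)/C=C/C(=O)O)c1`, 6230 nM
- compound 2 `CC(C)(C)c1ccc(C(=O)/C=C/C(=O)O)cc1`, 8740 nM

Both numbers come from a functional assay on LS174T cells (Homo sapiens) for inhibition, read by MTT assay, with a stated time of 72 h; a higher number here means a weaker inhibitor, a lower number a stronger inhibitor. Compound 2 carries the higher of the two numbers, but its distance to compound 1 lies within the usual scatter of repeated measurements, so the two compounds cannot be told apart on these data; neither is called the stronger or weaker inhibitor.

Compound 3 `O=C(O)/C=C/C(=O)c1ccc(Br)cc1` is the next compound to go into this assay. It differs from compound 2 in one place: bromo in place of tert-butyl on an aromatic carbon. Within the data shown here, no step between two measured compounds of this kind is available, so no measured precedent guides the expectation. Among the measured compounds shown here, with only a single-site exchange and no reference pair, the step expected is a 1.0-fold higher number from compound 2 to compound 3 (0.01 log units; within the scatter), a change not beyond the scatter in either direction.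

Compound 3 is thus estimated at 9000 nM in this assay, with a range from 3000 nM to 30000 nM.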

Compound 3, half-maximal inhibitory concentration: 27100 nM
Estimate against measurement, compound 3: 3.0-fold (0.48 log units) below; low and high end bracket the measured number.
By their numbers in this assay, from the lowest: compounds 1 and 2 (each within the scatter of the next); then compound 3.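

Among these compounds, exchanging tert-butyl for bromo on this aromatic carbon gives a 3.1-fold higher number from compound 2 to compound 3 (0.49 log units; beyond the scatter) in this assay, the first step that lies beyond the scatter. The position is therefore not indifferent to its substituent: in this pair, the group of 4 carbon atoms goes with the stronger inhibitor and the single bromine with the weaker one, though the step is modest in size. No measurement shown here bears on why the number moves.

A single pair cannot tell whether the number follows the size of the group at this carbon or something particular to bromo or tert-butyl. Going by these compounds, how a methyl, a methoxy group or an amine at the same carbon would read in this assay remains open, and any of these would help separate the two readings.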